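Branched secondary amine in place of a tertiary amine

The source may hold more compounds than are shown below. What is called first, only, known or untested is meant among the compounds shown, and "the series" means these compounds.

- compound 2 `CCCN(C)c1nc(C)nc2c(-c3c(C)cc(OC)cc3OC)c(C)nn12`: 6.48 nM
- compound 1 `CCN(CC)c1nc(C)nc2c(-c3ccc(OC)c(C)c3C)c(C)nn12`: 38.6 nM
- compound 3 `COc1ccc(-c2c(C)nn3c(N4CCCC4)nc(C)nc23)c(C)c1`: 80.7 nM

In an assay on cell membranes for displacement of a labelled ligand from corticotropin-releasing factor receptor 1 (Rattus norvegicus) (a higher number here means a weaker inhibitor, a lower number a stronger inhibitor), compound 2 gives the lowest of the three numbers, with compound 1 and compound 3 both well beyond the scatter above it. Compound 4 `CCC(CC)Nc1nc(C)nc2c(-c3c(C)cc(OC)cc3OC)c(C)nn12` is not yet measured. It differs from compound 2 by (pentan-3-yl)amino in place of methyl(propyl)amino on an aromatic carbon. Among the measured compounds shown here, no two measured compounds differ only at this position, so this particular change has no precedent here. The step expected from compound 2 to compound 4, a 1.4-fold higher number from compound 2 to compound 4 (0.14 log units; within the scatter), is small and might not exceed the scatter. Compound 4 is therefore estimated at 9 nM, with a range from 3 nM to 30 nM.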

Compound 4, half-maximal inhibitory concentration: 5 nM
Compound 4: middle estimate off by 1.8-fold (0.26 log units), on the high side, and the stated range covers the measured number.
By their numbers in this assay, from the lowest: compounds 4 and 2 (each within the scatter of the next); then compound 1; then compound 3.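

In this assay, (pentan-3-yl)amino in place of methyl(propyl)amino on the core of compound 2 gives a 1.3-fold lower number from compound 2 to compound 4 (0.11 log units; within the scatter), which is within the scatter. This position therefore accepts a secondary amine carrying a hydrogen-bond donor as well as a tertiary amine without one, and the two cannot be told apart by their numbers. Nothing given here accounts for this result. From the compounds shown here alone, it remains open whether a morpholine or a benzylamino group at this position would give a similar number, and whether (pentan-3-yl)amino would behave the same way on the cores of compound 1 and compound 3.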